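A few compounds are considered here, and "the series" means these few. Any claim that something is new, unique, unknown or untested is made for them only; others in the source may bear on it.

Working notes on the series, all read in an assay on isolated protein for inhibition of Amine oxidase [flavin-containing] B (Homo sapiens), read by fluorescence and Amplex Red, with a stated time of 15 min; on this read-out lower numbers stand for stronger inhibition and higher numbers for weaker inhibition.

Compound 1 `C#CCN(CC)Cc1cn(-c2cc(NC(=S)NCC)ncn2)cn1` is the parent of the set. In this assay compound 1 gives only a limit, > 50000 nM. Compound 2 `C#CCN(CCC)Cc1cn(-c2cc(NC(=S)NCC)ncn2)cn1` carries one more carbon on the chain. In this assay compound 2 likewise gives only a limit, > 50000 nM. Compound 3 `C#CCN(CC#N)Cc1cn(-c2cc(NC(=S)NCC)ncn2)cn1` carries a nitrile-bearing chain on the amine nitrogen. In this assay compound 3 also gives only a limit, > 50000 nM. Every value shown so far sits at the limit of > 50000 nM in this assay, at which 3 of the 3 values shown sit, so compound 3 stands nowhere that can be ranked: the step that the two limits leave unreadable from compound 1 to compound 3 and the step that the two limits leave unreadable from compound 2 to compound 3 are both unreadable, as is a step that the two limits leave unreadable from compound 1 to compound 2.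

Compound 4 `C#CCNCCCc1cn(-c2cc(NC(=S)NCC)ncn2)cn1` differs from compound 3 by a group of 6 heavy atoms (5 carbon, 1 nitrogen; no ring) in place of a group of 7 heavy atoms (5 carbon, 2 nitrogen; no ring), on a saturated chain carbon bound to an aromatic carbon. None of the three measured steps gives a readable size, so no direction can be taken from them; the change removes the nitrile and makes the amine a hydrogen-bond donor, but nothing measured here speaks to that. The expectation for compound 4 is therefore a value near the limit, estimated at 40000 nM with a range of 4000 nM to 200000 nM, which means an expected step of an at least 1.2-fold lower number from compound 3 to compound 4 (0.09 log units; that floor lies within the scatter).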

Compound 4, half-maximal inhibitory concentration: > 50000 nM
Compound 4 was reported as a limit; the forecaster's own chance of this, stated with the estimate: 60%; at least 1.2-fold (0.09 log units) between middle value and limit.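

In this assay compound 4 gives only a limit, > 50000 nM. Within the data shown here, no step from compound 1, compound 2 or compound 3 to compound 4 can be read, as all four compounds share one limit: the limit of > 50000 nM in this assay, at which 4 of the 4 values shown sit. The compounds shown leave open how far any of these changes on the shared core moves inhibition, and whether any of the four differs from the others at all.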